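The source may hold more compounds than are shown below. What is called first, only, known or untested is meant among the compounds shown, and "the series" means these compounds.

The series shares one core, seen in compound 1 `Cc1nnc(SCC(=O)c2ccc(Cl)cc2)n1N1C(=O)c2ccccc2C1=O`, compound 2 `CSc1nnc(C)n1N1C(=O)c2ccccc2C1=O` and compound 3 `Cc1nnc(SCc2ccccc2Cl)n1N1C(=O)c2ccccc2C1=O`. In a functional assay on PC-3M cells (Homo sapiens) for cytotoxicity, read by MTT assay, with a stated time of 48 h (on this read-out higher numbers stand for weaker inhibition and lower numbers for stronger inhibition), compound 1 gives > 200000 nM, which is a limit of the assay and not a number. In this assay compound 2 gives > 200000 nM, again a limit. In this assay compound 3 gives > 200000 nM, also a limit. The steps among the three, a step that the two limits leave unreadable from compound 1 to compound 2, a step that the two limits leave unreadable from compound 1 to compound 3 and a step that the two limits leave unreadable from compound 2 to compound 3, cannot be sized because of the limit of > 200000 nM in this assay, at which 3 of the 3 values shown sit. Compound 3 therefore stands only at a limit, with nothing in the numbers to set it apart from the other two.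

Compound 4 `COc1cc(-c2nnc(SCc3ccccc3Cl)n2N2C(=O)c3ccccc3C2=O)cc(OC)c1OC` differs from compound 3 by 3,4,5-trimethoxyphenyl in place of methyl on an aromatic carbon. For the measured compounds named here, no measured step touches this position; the three measured steps all concern the saturated chain carbon bound to a sulfur, and none of them is readable. The expectation for an at least 1.6-fold lower number from compound 3 to compound 4 (0.22 log units; that floor lies within the scatter) thus rests on no measured step and is estimated only loosely, with a move toward stronger inhibition held as possible but unsupported by the shown values. Compound 4 is expected to give 120000 nM in this assay, in a range of 30000 nM to 300000 nM, with a real chance that the assay again reports only a limit.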

Compound 4, half-maximal inhibitory concentration: > 200000 nM
Compound 4 gave a limit, no number; the forecaster's own chance of this, stated with the estimate: 50%; middle value at least 1.6-fold (0.22 log units) away from the limit.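

In this assay compound 4 gives > 200000 nM, a limit and not a number. The step from compound 3 to compound 4 cannot be read, because the values stop at one shared limit: the limit of > 200000 nM in this assay, at which 4 of the 4 values shown sit. The compounds shown leave open whether any change on the shared core, at either position, shifts the read-out at all.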